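A few compounds are considered here, and "the series" means these few. Any claim that something is new, unique, unknown or untested is made for them only; others in the source may bear on it.

Measured so far in a functional assay on the whole organism (strain Wistar albino) for inhibition, with Rattus norvegicus as the target, read by paw edema, with stated times of 30 min and 4 h, at a dose of 20 mg/kg by the oral route; a lower number here means less inhibition, a higher number more inhibition at the dose given (going by the name of the read-out): compound 1 `COc1ccc(NCC(=O)Oc2ccc3c(C)cc(=O)oc3c2)cc1` gives 28.8%; compound 2 `COc1ccccc1NCC(=O)Oc1ccc2c(C)cc(=O)oc2c1` gives 19.4%; compound 3 `Cc1cc(=O)oc2cc(OC(=O)CNc3ccccc3Cl)ccc12` gives 23.7%.

Compound 3 stands second highest of the three; its nearest neighbour is compound 2, a number 4.3 percentage points higher from compound 2 to compound 3 (within the scatter), and the furthest is compound 1, a number 5.1 percentage points lower from compound 1 to compound 3 (within the scatter). All three lie within the scatter of one another.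

Compound 4 `Cc1cc(=O)oc2cc(OC(=O)CNc3ccc(Cl)cc3)ccc12` differs from compound 3 only in the arylamine: 4-chlorophenyl in place of 2-chlorophenyl on an amine nitrogen. Among the compounds with values here, the one step that bears on this is the same positional exchange within the methoxy pair, a number 9.4 percentage points lower from compound 1 to compound 2 (within the scatter), run here in the opposite direction. A step of similar small size upward, not beyond the scatter, is therefore expected: a number 6.3 percentage points higher from compound 3 to compound 4 (within the scatter). Compound 4 is estimated at 30%, range 18% to 42%.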

Compound 4, a percentage reported as inhibition, in the whole organism at one dose (the size of the read-out at that dose, not a potency): 16.1%
The estimate for compound 4 lay 13.9 percentage points above the measured number; measured number outside the range, below it.
By their numbers in this assay, from the lowest: compounds 4, 2, 3 and 1 (each within the scatter of the next, the first and the last beyond it).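

In this assay, 4-chlorophenyl in place of 2-chlorophenyl on an amine nitrogen gives a number 7.6 percentage points lower from compound 3 to compound 4 (within the scatter), and 4-chlorophenyl in place of 2-methoxyphenyl gives a number 3.3 percentage points lower from compound 2 to compound 4 (within the scatter). Chloro in place of methoxy on an aromatic carbon gives the first step beyond the scatter, a number 12.7 percentage points lower from compound 1 to compound 4 (beyond the scatter). That exchange therefore does not carry over unchanged from one arylamine to the other: the same change on two cores in this assay, a number 4.3 percentage points higher (within the scatter) from compound 2 to compound 3 and a number 12.7 percentage points lower (beyond the scatter) from compound 1 to compound 4, 17 percentage points apart, beyond the scatter of two such steps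

Still open, going by these compounds, is how an unsubstituted phenyl on the amine nitrogen compares with these four aryl groups. Also open, on these data alone, is whether a methyl or a carboxylic acid on that ring would follow the chloro pair or the methoxy pair.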